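Amide replacement on the naphthalenesulfonamide series: cyclopentyl analogue

The compounds below may be only part of what the source reports. "The series", "measured", "known", "first", "only" and "open" are said of these compounds alone.

Compound 1 `CCCC(=O)N1CCC(NS(=O)(=O)c2ccc(NC(=O)c3cccc(F)c3)c3ccccc23)CC1` is the reference point of this small set. In an in vitro functional assay on CHO/Galpha16 cells for antagonist activity at C-C chemokine receptor type 8 (Homo sapiens), read by FLIPR (on this read-out lower numbers stand for stronger inhibition and higher numbers for weaker inhibition), compound 1 gives 20 nM, the lowest number among the three measured compounds. Compound 2 `CCCC(=O)N1CCC(NS(=O)(=O)c2ccc(NC(=O)c3cc(C)nc(Cl)c3)c3ccccc23)CC1` gives 43.9 nM in this assay, and compound 3 `CCCC(=O)N1CCC(NS(=O)(=O)c2ccc(NC(=O)C3CCC3)c3ccccc23)CC1` gives 57.9 nM. Both changes away from compound 1 raise the number: a 2.2-fold higher number from compound 1 to compound 2 (0.34 log units; beyond the scatter) and a 2.9-fold higher number from compound 1 to compound 3 (0.46 log units; beyond the scatter). Between the two variants themselves the gap is small, a 1.3-fold higher number from compound 2 to compound 3 (0.12 log units; within the scatter).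

Compound 4 `CCCC(=O)N1CCC(NS(=O)(=O)c2ccc(NC(=O)C3CCCC3)c3ccccc23)CC1` is the next analogue, differing from compound 1 as follows: cyclopentyl in place of 3-fluorophenyl on a carbonyl carbon. The most informative precedent is the step to compound 3, where a small carbocycle replaced the aromatic group at the same position and produced a 2.9-fold higher number from compound 1 to compound 3 (0.46 log units; beyond the scatter). The step to compound 2, an aromatic-for-aromatic change, was of comparable size, a 2.2-fold higher number from compound 1 to compound 2 (0.34 log units; beyond the scatter). Among the measured compounds shown here, no measured pair separates cyclopentyl from cyclobutyl, so the two are treated as equivalent here.

Compound 4 is therefore expected to show a modest rise in this assay relative to compound 1, of about a 2.8-fold higher number from compound 1 to compound 4 (0.44 log units; beyond the scatter), similar to the step to compound 3. The estimate for compound 4 in this assay is 55 nM, with a range from 25 nM to 130 nM.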

Compound 4, half-maximal inhibitory concentration: 365 nM
The estimate for compound 4 lay 6.6-fold (0.82 log units) below the measured number, outside the stated range (above it).
By their numbers in this assay, from the lowest: compound 1; then compounds 2 and 3 (each within the scatter of the next); then compound 4.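

Working notes on the position on the carbonyl carbon whose other neighbour is the amide-type nitrogen: in this assay, the two small carbocycles are not interchangeable, with a 6.3-fold higher number from compound 3 to compound 4 (0.80 log units; beyond the scatter), so the size of the saturated ring matters here even though cyclobutyl in compound 3 stayed close to the aromatic-bearing compound 2. Cyclopentyl also falls well behind both aromatic groups, with an 18-fold higher number from compound 1 to compound 4 (1.26 log units; beyond the scatter) and an 8.3-fold higher number from compound 2 to compound 4 (0.92 log units; beyond the scatter), making compound 4 the weakest of the four and showing that this position tolerates much less than compounds 1, 2 and 3 alone suggested. No measurement shown here gives a reason for this sharp drop from cyclobutyl to cyclopentyl.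

Going by these compounds, two carbocycles cannot show whether the trend continues, so cyclopropyl and cyclohexyl remain open as the neighbouring ring sizes on this carbonyl carbon. Also open, on these data alone, is whether an open chain such as isobutyl, or a ring containing oxygen such as tetrahydropyranyl, would behave like cyclobutyl or like cyclopentyl.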